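From a hydroxyacetyl piperidine to a cyclopropylsulfonyl pyrrolidine

The compounds below may be only part of what the source reports. "The series", "measured", "known", "first", "only" and "open" are said of these compounds alone.

Compound 1 `CN1CCN(c2ccc(Nc3ncc4nc(Nc5ccc(F)cc5)n([C@H]5CCCN(C(=O)CO)C5)c4n3)cc2)CC1`: 830 nM
Compound 2 `CN1CCN(c2ccc(Nc3ncc4nc(Nc5ccccc5)n([C@H]5CCN(C(=O)OC(C)(C)C)C5)c4n3)cc2)CC1`: "not determined" (no result reported)
Compound 3 `CN1CCN(c2ccc(Nc3ncc4nc(Nc5ccccc5)n([C@H]5CCNC5)c4n3)cc2)CC1`: "not determined" (no result reported)

For the measured compounds named here, in a functional assay on A549 cells (Homo sapiens) for antiproliferative activity, read by MTT assay, with a stated time of 72 h (on this read-out lower numbers stand for stronger inhibition and higher numbers for weaker inhibition), compound 1 gives 830 nM, the only number in this set. Going by the values given here, for compound 2 the entry is "not determined" (no result reported), and for compound 3 it is "not determined" (no result reported), so compound 1 stands alone and no step between measured compounds can be drawn. Compound 4 `CN1CCN(c2ccc(Nc3ncc4nc(Nc5ccc(F)cc5)n([C@@H]5CCN(S(=O)(=O)C6CC6)C5)c4n3)cc2)CC1` differs from compound 1 in one place: 1-(cyclopropylsulfonyl)pyrrolidin-3-yl in place of 1-((hydroxymethyl)carbonyl)piperidin-3-yl on an aromatic nitrogen. With nothing to compare, the step is expected to stay within the usual scatter, perhaps a slight gain. Compound 4 is therefore estimated at 600 nM, in the range 150 nM to 2500 nM, a step of a 1.4-fold lower number from compound 1 to compound 4 (0.14 log units; within the scatter).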

Compound 4, half-maximal inhibitory concentration: > 10000 nM
Compound 4: only a limit was reported (the forecaster's own chance of this, stated with the estimate: 5%); middle value at least 16-fold (1.22 log units) away from the limit.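

The group on the aromatic nitrogen matters for activity in the shared core: 1-(cyclopropylsulfonyl)pyrrolidin-3-yl in place of 1-((hydroxymethyl)carbonyl)piperidin-3-yl gives an at least 12-fold higher number from compound 1 to compound 4 (1.08 log units; beyond the scatter). In this assay compound 4 reads > 10000 nM, which is a limit of the assay and not a number. The size of the step therefore rests on that limit: the limit of > 10000 nM in this assay, at which 1 of the 4 values shown sits.

For the compounds shown here, the single step changes both the ring and the group on its nitrogen, and it leaves open which of them accounts for the loss. Going by these compounds alone, a 1-(cyclopropylsulfonyl)piperidin-3-yl group at this place would separate the two, while compound 2 and compound 3, which have no numbers, offer no steps that can be read.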